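One More Methoxy Group, and What to Expect

A few compounds are considered here, and "the series" means these few. Any claim that something is new, unique, unknown or untested is made for them only; others in the source may bear on it.

In an ADME assay on CCRF-CEM cells (Homo sapiens) for antiproliferative activity, with a stated time of 48 h (on this read-out higher numbers stand for weaker inhibition and lower numbers for stronger inhibition), compound 1 (`C=C(Br)C(=O)Nc1ccc(C(=O)/C=C/c2cccc(OC)c2)cc1`) gives 1800 nM, compound 2 (`C=C(Br)C(=O)Nc1ccc(C(=O)/C=C/c2ccc(OC)c(OC)c2)cc1`) gives 1600 nM and compound 3 (`C=C(Br)C(=O)Nc1ccc(C(=O)/C=C/c2cc(OC)cc(OC)c2)cc1`) gives 2200 nM. These values lie within the scatter of one another, so compound 3 is not set apart from either of the other two. Compound 4 (`C=C(Br)C(=O)Nc1ccc(C(=O)/C=C/c2cc(OC)c(OC)c(OC)c2)cc1`) differs from compound 3 by a single change, (methoxy in place of hydrogen on an aromatic carbon), which is methoxy in place of hydrogen on an aromatic carbon. Two measured steps are of this same kind: a 1.1-fold lower number from compound 1 to compound 2 (0.05 log units; within the scatter) and a 1.2-fold higher number from compound 1 to compound 3 (0.09 log units; within the scatter). Both lie within the scatter, so neither gives grounds to expect a real shift. Within the data shown here, no measured compound has a methoxy ortho to two methoxy groups, however, so this placement remains untested and the range is kept wide. No change beyond the scatter is expected, and the estimated step is a 1.2-fold lower number from compound 3 to compound 4 (0.09 log units; within the scatter). For compound 4 the expected value is 1800 nM, with an estimated range from 800 nM to 3800 nM.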

Compound 4, half-maximal inhibitory concentration: 330 nM
For compound 4 the middle estimate is 5.5-fold (0.74 log units) above the measured one; the measured number lies below the stated range.
By their numbers in this assay, from the lowest: compound 4; then compounds 2, 1 and 3 (each within the scatter of the next).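

In this assay, methoxy in place of hydrogen on an aromatic carbon, here ortho to two methoxy groups, gives a 6.7-fold lower number from compound 3 to compound 4 (0.82 log units; beyond the scatter), and the same kind of change made on compound 2 gives a 4.8-fold lower number from compound 2 to compound 4 (0.69 log units; beyond the scatter). The earlier steps shown here of this kind stayed within the scatter, whereas these show that the size of the change depends on the core receiving it: the same change on two cores in this assay, a 1.1-fold lower number (0.05 log units; within the scatter) from compound 1 to compound 2 and a 6.7-fold lower number (0.82 log units; beyond the scatter) from compound 3 to compound 4, 5.9-fold (0.77 log units) apart, beyond the scatter of two such steps. The second pair of steps points the same way: the same change on two cores in this assay, a 1.2-fold higher number (0.09 log units; within the scatter) from compound 1 to compound 3 and a 4.8-fold lower number (0.69 log units; beyond the scatter) from compound 2 to compound 4, 5.9-fold (0.77 log units) apart, beyond the scatter of two such steps.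

The compounds shown leave open whether the step requires this particular placement or the full set of three methoxy groups on the ring. They also leave open whether an ethoxy, a hydroxy or an amine at this position would give a step of similar size.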